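Chloro on the phenyl of compound 3

The compounds below may be only part of what the source reports. "The series", "measured", "known", "first", "only" and "open" are said of these compounds alone.

Measured in a functional assay on K562 cells (Homo sapiens) for cytotoxicity, read by MTT assay, with a stated time of 48 h (on this read-out lower numbers stand for stronger inhibition and higher numbers for weaker inhibition), so far:
compound 1 `COc1ccc(-c2c[nH]c(=O)n2-c2cc(OC)c(OC)c(OC)c2)cc1N` gives 49200 nM
compound 2 `COc1cc(NC(=O)n2cc(-c3ccc(O)cc3)n(-c3cc(OC)c(OC)c(OC)c3)c2=O)cc(OC)c1OC` gives 10400 nM
compound 3 `COc1cc(-n2c(-c3ccccc3)cn(C(C)=O)c2=O)cc(OC)c1OC` gives > 50000 nM (a limit, not a number)

Compound 3 stands at the limit of > 50000 nM in this assay, at which 1 of the 3 values shown sits, and has no number. The next compound is compound 4 `COc1cc(-n2c(-c3ccc(Cl)cc3)cn(C(C)=O)c2=O)cc(OC)c1OC` with chloro in place of hydrogen on an aromatic carbon, phenyl to 4-chlorophenyl, counted as chloro in place of hydrogen on an aromatic carbon and nothing else altered. Within the data shown here, no measured step covers this change, so only a small move in this assay toward stronger inhibition is expected. The expected step is an at least 1.2-fold lower number from compound 3 to compound 4 (0.09 log units; that floor lies within the scatter) and it is small in size. Expected for compound 4 is 40000 nM with an estimated range of 15000 nM to 80000 nM and a real chance of another limit reading.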

Compound 4, half-maximal inhibitory concentration: > 50000 nM
Compound 4: no number, only a limit (the forecaster's own chance of this, stated with the estimate: 45%); middle value at least 1.2-fold (0.09 log units) away from the limit.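

Compound 3 and compound 4 both read as limits in this assay and not as numbers, so no step can be read between them: the limit of > 50000 nM in this assay, at which 2 of the 4 values shown sit.

Going by these compounds, whether phenyl to 4-chlorophenyl moves the read-out at all stays open.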